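Series notes: ring nitrogen swap on the indazolyl arm

The source may report more compounds than this note shows. Statements on the series, on what has been measured and on what is new or still open speak of the compounds shown alone.

Measured compounds in a functional assay on MCF7 cells (Homo sapiens) for cytotoxicity, read by CellTiter-Glo, with a stated time of 5 days; on this read-out higher numbers stand for weaker inhibition and lower numbers for stronger inhibition:
compound 1 `CC/C(=C(/c1ccc(/C=C/C(=O)O)cc1)c1ccc2[nH]ncc2c1)c1ccccc1`: 7.2 nM
compound 2 `O=C(O)/C=C/c1ccc(/C(=C(/CCO)c2ccccc2)c2ccc3[nH]ncc3c2)cc1`: a limit of the assay, > 1000 nM
compound 3 `O=C(O)/C=C/c1ccc(/C(=C(\c2ccccc2)C2CCC2)c2ccc3[nH]ncc3c2)cc1`: 1.4 nM

Compound 1 stands highest of the two numbers shown; its nearest neighbour is compound 3, with a 5.1-fold lower number from compound 1 to compound 3 (0.71 log units; beyond the scatter). The reading for compound 2 is a limit of the assay, and the limit of > 1000 nM in this assay, at which 1 of the 3 values shown sits, marks where it sits. All measured steps alter the substituent on the double-bonded chain carbon: an at least 130-fold higher number from compound 1 to compound 2 (2.14 log units; beyond the scatter), a 5.1-fold lower number from compound 1 to compound 3 (0.71 log units; beyond the scatter) and an at least 710-fold lower number from compound 2 to compound 3 (2.85 log units; beyond the scatter). Compound 4 `CC/C(=C(/c1ccc(/C=C/C(=O)O)cc1)c1cc2cn[nH]c2cn1)c1ccccc1` leaves that substituent untouched and instead alters the aromatic arm on the same carbon: a group of 9 heavy atoms (6 carbon, 3 nitrogen; one five-membered aromatic ring with 2 hetero atoms, one six-membered aromatic ring with 1 hetero atom) in place of a group of 9 heavy atoms (7 carbon, 2 nitrogen; one five-membered aromatic ring with 2 hetero atoms, one six-membered aromatic ring of carbon only), on a double-bonded chain carbon bound to an aromatic carbon and a double-bonded chain carbon. Going by the values given here, no measured step touches this arm, so the measured steps give no direct guide to its effect. With the remaining structure held constant, the step from compound 1 to compound 4 is expected to be a 2.1-fold higher number from compound 1 to compound 4 (0.32 log units; beyond the scatter), a change no larger than modest in this assay. Compound 4 is therefore estimated at 15 nM, with a range from 4 nM to 60 nM.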

Compound 4, half-maximal inhibitory concentration: 442 nM
The estimate for compound 4 lay 29-fold (1.47 log units) below the measured number; the whole stated range lies below it.
By their numbers in this assay, from the lowest: compound 3; then compound 1; then compound 4. At a limit, above all of these: compound 2.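

In this assay, replacing the 1H-indazol-5-yl arm with the arm whose six-membered aromatic ring holds 1 hetero atom gives a 61-fold higher number from compound 1 to compound 4 (1.79 log units; beyond the scatter). Going by these compounds alone, the earlier steps altered only the other substituent on the double-bonded chain carbon, so this is the first sign that the aromatic arm at this place is also sensitive, even though the heavy-atom count, the single hydrogen-bond donor and the absence of net charge all stay the same. The only change in the counts is a second hydrogen-bond acceptor, and no measurement shown here accounts for the size of the step.

From the compounds shown here alone, it remains open whether the new arm has a similar effect when paired with the cyclobutyl group of compound 3. Going by these compounds, it is also open how an indol-5-yl arm or a benzimidazol-5-yl arm would read on the core of compound 1.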